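The source may hold more compounds than are shown below. What is called first, only, known or untested is meant among the compounds shown, and "the series" means these compounds.

Going by the values given here, compound 2 `Cc1cnc(Nc2ccc(S(C)(=O)=O)cc2)nc1Nc1nc2ccccc2s1` gives 460 nM in a functional assay on HeLa cells (Homo sapiens) for antiproliferative activity, read by MTT assay, with a stated time of 48 h (on this read-out higher numbers stand for weaker inhibition and lower numbers for stronger inhibition), the lower of the two numbers measured so far. Among the compounds with values here, its only companion is compound 1 `Cc1cnc(Nc2ccc([N+](=O)[O-])cc2)nc1Nc1nc2ccccc2s1`, which in this assay gives 34300 nM. The two are built alike except for one group on a six-membered aromatic ring of carbon only, and exchanging that group produced a 75-fold lower number from compound 1 to compound 2 (1.87 log units; beyond the scatter). Compound 3 `Cc1cnc(Nc2ccc(N3CCCCC3)cc2)nc1Nc1nc2ccccc2s1` is the next move from compound 2, with piperidin-1-yl in place of methylsulfonyl on an aromatic carbon. Within the data shown here, no measured pair involves piperidin-1-yl, so the single known step, large as it is, shows only that the group at this place can shift the number strongly, without saying which way a new group will push it. Compound 3 is therefore expected to give about 3000 nM, somewhere between 300 nM and 30000 nM. That estimate means an expected 6.5-fold higher number from compound 2 to compound 3 (0.81 log units; beyond the scatter), and it is kept wide since a single comparison supports it.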

Compound 3, half-maximal inhibitory concentration: 4340 nM
For compound 3 the middle estimate is 1.4-fold (0.16 log units) below the measured one; measured number inside the range.
By their numbers in this assay, from the lowest: compound 2; then compound 3; then compound 1.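

With a third group at this place, the numbers can now be put in order: piperidin-1-yl in place of methylsulfonyl gives a 9.4-fold higher number from compound 2 to compound 3 (0.97 log units; beyond the scatter) while piperidin-1-yl in place of nitro gives a 7.9-fold lower number from compound 1 to compound 3 (0.90 log units; beyond the scatter) and so the newcomer falls between the two earlier groups. This position therefore gives a graded series of outcomes rather than one high and one low number, and methylsulfonyl remains the group with the lowest number of the three. No measured evidence explains this ranking.

Going by these compounds, three groups are too few to show what sets the order, so it remains open whether a primary amine, a carboxylic acid or a morpholine ring at this place would give a number lower than that of compound 2. On these data alone, whether the ranking would hold with changes elsewhere on the shared core also remains open.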